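A few compounds are considered here, and "the series" means these few. Any claim that something is new, unique, unknown or untested is made for them only; others in the source may bear on it.

In a functional assay on HL-60 cells (Homo sapiens) for cytotoxicity, read by WST assay, with a stated time of 48 h (a lower number here means that less compound is needed, a higher number that more compound is needed for the effect), compound 1 (`O=C1OC[C@H](Cc2ccccc2)[C@H]1Cc1ccc(O)cc1`) gives 88000 nM, compound 2 (`Clc1ccc(C[C@H]2COC[C@@H]2Cc2ccccc2)cc1Cl`) gives 19000 nM and compound 3 (`Oc1ccccc1C[C@H]1COC[C@@H]1Cc1ccc(Cl)c(Cl)c1`) gives 34000 nM. Compound 3 therefore lies within the usual scatter of compound 2, while its number is lower than that of compound 1 by more than the scatter. Compound 4 (`COc1ccccc1C[C@H]1COC[C@@H]1Cc1ccc(Cl)c(Cl)c1`) differs from compound 3 in one place: methyl in place of hydrogen on an oxygen on an aromatic ring, or hydroxy to methoxy. The closest measured step is hydroxy in place of hydrogen on an aromatic carbon, a 1.8-fold higher number from compound 2 to compound 3 (0.25 log units; within the scatter). That single step gives no firm direction, so no change beyond the scatter is expected in this assay. The expected step is a 1.1-fold lower number from compound 3 to compound 4 (0.05 log units; within the scatter). For compound 4 the estimated value is 30000 nM, with an expected range from 14000 nM to 65000 nM.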

Compound 4, half-maximal effective concentration: 55000 nM
Compound 4: the middle estimate sits 1.8-fold (0.26 log units) below what was measured; measured number inside the range.
By their numbers in this assay, from the lowest: compounds 2, 3, 4 and 1 (each within the scatter of the next, the first and the last beyond it).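

In this assay, putting methyl on the oxygen on an aromatic ring gives a 1.6-fold higher number from compound 3 to compound 4 (0.21 log units; within the scatter), so hydroxy and methoxy cannot be told apart at this position. Set against hydrogen on the aromatic carbon, however, methoxy gives a 2.9-fold higher number from compound 2 to compound 4 (0.46 log units; beyond the scatter), a modest step that the hydroxy step alone did not show. No evidence is available to explain either step.

On these data alone, it remains open whether a longer chain on this oxygen, such as ethyl, would extend this small trend. An amine in the same place is also untested among the compounds shown.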